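Swapping a Methoxyphenyl for an Imidazole on the Core

This account rests on a few compounds, and the source may have more. Where it says the series, first, only, none or still open, it means among the compounds named here.

Compound 1 `COc1ccccc1Cc1cn(C2CC2)c2c(F)c(-c3cc(C)nc(C)c3)c(F)cc2c1=O` has, in a functional assay on P388 cells (Mus musculus) for cytotoxicity (on this read-out higher numbers stand for weaker inhibition and lower numbers for stronger inhibition), a value of 37000 nM, the higher of the two numbers seen here. Compound 2 `Cc1cc(-c2c(F)cc3c(=O)c(Cc4ncc[nH]4)cn(C4CC4)c3c2F)cc(C)n1` gives 1100 nM in this assay, and the step of a 34-fold lower number from compound 1 to compound 2 (1.53 log units; beyond the scatter) came with 1H-imidazol-2-yl in place of 2-methoxyphenyl on a saturated chain carbon bound to an aromatic carbon. Compound 3 `Cc1cc(-c2c(F)cc3c(=O)c(Cc4c[nH]cn4)cn(C4CC4)c3c2F)cc(C)n1` differs from compound 1 as follows: 1H-imidazol-4-yl in place of 2-methoxyphenyl on a saturated chain carbon bound to an aromatic carbon. Because that change closely resembles the measured step of a 34-fold lower number from compound 1 to compound 2 (1.53 log units; beyond the scatter), a step of similar size in the same direction is expected, a 25-fold lower number from compound 1 to compound 3 (1.39 log units; beyond the scatter). Compound 3 is therefore estimated at 1500 nM, within 400 nM to 6000 nM.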

Compound 3, half-maximal inhibitory concentration: 390 nM
Compound 3: middle estimate off by 3.8-fold (0.59 log units), on the high side; the whole stated range lies above it.
By their numbers in this assay, from the lowest: compound 3; then compound 2; then compound 1.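

The point at which the imidazole ring is attached matters here: 1H-imidazol-4-yl in place of 1H-imidazol-2-yl gives a 2.8-fold lower number from compound 2 to compound 3 (0.45 log units; beyond the scatter), a modest step that still lies beyond the scatter. Against 2-methoxyphenyl, 1H-imidazol-4-yl gives a 95-fold lower number from compound 1 to compound 3 (1.98 log units; beyond the scatter), the largest step seen so far. No measurement available here explains the difference between the two imidazoles. On these data alone, whether the lower number needs an imidazole at all stays open. The compounds shown do not tell how a pyrazole, an amine or a carboxylic acid on the same saturated chain carbon would read.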